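This account rests on a few compounds, and the source may have more. Where it says the series, first, only, none or still open, it means among the compounds named here.

Measured compounds:
Compound 1, `N#CC1=C(N)Oc2c(N)cc3nc4ccccc4nc3c2C12C(=O)N(Cc1cnnn1-c1ccc(Cl)cc1)c1ccccc12`: in an ADME assay on HUVEC cells (Homo sapiens) for antiproliferative activity, read by MTT assay, with a stated time of 48 h (a lower number here means a stronger inhibitor, a higher number a weaker inhibitor), compound 1 gives > 50000 nM, a limit of the assay rather than a number.
Compound 2, `N#CC1=C(N)Oc2c(N)cc3nc4ccccc4nc3c2C12C(=O)N(Cc1cnnn1-c1cccc(Br)c1)c1ccccc12`: compound 2 gives > 50000 nM, again a limit of the assay.
Compound 3, `N#CC1=C(N)Oc2c(N)cc3nc4ccccc4nc3c2C12C(=O)N(Cc1cnnn1-c1ccccc1Br)c1ccccc12`: compound 3 gives 34200 nM.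

Compound 3 is the only one of the three with an actual number; the other two values are limits, as the limit of > 50000 nM in this assay, at which 2 of the 3 values shown sit, records. For the measured compounds named here, the two steps that end at compound 3 are an at least 1.4-fold lower number from compound 1 to compound 3 (0.16 log units; that floor lies within the scatter) and an at least 1.4-fold lower number from compound 2 to compound 3 (0.16 log units; that floor lies within the scatter), each a floor lying within the scatter, so they show little more than that compound 3 is the one compound with a readable value. The step that the two limits leave unreadable from compound 1 to compound 2 cannot be read at all. Compound 4, `CC(=O)Nc1ccc(-n2nncc2CN2C(=O)C3(C(C#N)=C(N)Oc4c(N)cc5nc6ccccc6nc5c43)c3ccccc32)cc1`, differs from compound 3 by 4-acetamidophenyl in place of 2-bromophenyl on an aromatic nitrogen. Going by the values given here, no measured step covers such a change; the two that touch it only show that exchanging one halophenyl for another barely crosses the limit. The expected step of a 1.5-fold higher number from compound 3 to compound 4 (0.16 log units; within the scatter) is therefore no larger than the scatter, in either direction. Compound 4 is estimated at 50000 nM, with a range from 20000 nM to 150000 nM, and a fair chance that only a limit is reported.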

Compound 4, half-maximal inhibitory concentration: > 50000 nM
Compound 4: only a limit was reported (the forecaster's own chance of this, stated with the estimate: 60%); the middle value lies on the limit itself.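

With 4-acetamidophenyl, this position carries a phenyl ring bearing something other than a halogen, and in this assay compound 4 gives > 50000 nM as a limit of the assay and not a number. For the compounds shown here, the one step with a floor is an at least 1.4-fold higher number from compound 3 to compound 4 (0.16 log units; that floor lies within the scatter) and it gives no sign of a stronger inhibitor, while the steps from compound 1 and from compound 2 cannot be read. So the acetamido group does not bring the compound to a readable value, and the same ceiling now holds most of the set: the limit of > 50000 nM in this assay, at which 3 of the 4 values shown sit.

From the compounds shown here alone, what a free amine or a carboxylic acid on the phenyl ring would do here stays open, as does a plain alkyl chain in place of the ring. Going by these compounds alone, also open is whether the place of the bromine matters, with compound 3 the only readable value.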